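The compounds below may be only part of what the source reports. "The series", "measured", "known", "first", "only" and "open" are said of these compounds alone.

Agonist activity was followed in a functional assay on HEK293 cells for agonist activity at Free fatty acid receptor 1 (Homo sapiens), read by HTRF and inositol phosphate accumulation, with a stated time of 60 min; on this read-out lower numbers stand for an effect already at smaller amounts and higher numbers for an effect only at larger amounts of compound. Among the compounds with values here, compound 2 `O=C(O)CC[C@H]1CCc2cc(-c3cc(OC(F)(F)F)ccc3F)ccc2O1` is the one compound with a number here: in this assay compound 2 gives 2100 nM. Compound 1 `COc1cc(OC2CCC2)nc(-c2ccc3c(c2)CC[C@H](CCC(=O)O)O3)c1F` in this assay gives only > 10000 nM, which is a limit of the assay rather than a number. Compound 3 `COc1cc(OC2CCC2)nc(-c2ccc3c(c2)CC[C@H]([C@@H]2C[C@H]2C(=O)O)O3)c1F` likewise gives > 10000 nM, again a limit. The change between them, (2-carboxycyclopropyl in place of 2-carboxyethyl on a saturated ring carbon), produced a step that the two limits leave unreadable from compound 1 to compound 3, since the limit of > 10000 nM in this assay, at which 2 of the 3 values shown sit, holds both ends of it. How the core of compound 2 differs from that of compound 1 is not broken down here. Compound 4 `O=C(O)[C@@H]1C[C@H]1[C@H]1CCc2cc(-c3cc(OC(F)(F)F)ccc3F)ccc2O1` carries the same change on the core of compound 2: 2-carboxycyclopropyl in place of 2-carboxyethyl on a saturated ring carbon. The place is described in the same words for both pairs, so this is the same change, not merely the same kind. For compound 4 the expected step is a 1.0-fold higher number from compound 2 to compound 4 (0.02 log units; within the scatter), close to no change but with wide room on either side. That expectation rests on a step that the two limits leave unreadable from compound 1 to compound 3 offering no readable size for this change. Compound 4 is therefore estimated at 2200 nM in this assay, with a likely range from 500 nM to 9000 nM.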

Compound 4, half-maximal effective concentration: > 10000 nM
Compound 4 was reported as a limit; the forecaster's own chance of this, stated with the estimate: 25%; at least 4.5-fold (0.65 log units) between middle value and limit.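

On the core of compound 2, putting 2-carboxycyclopropyl in place of 2-carboxyethyl gives an at least 4.7-fold higher number from compound 2 to compound 4 (0.67 log units; beyond the scatter) in this assay, so on this core the change moves the effect to larger amounts of compound. In that assay compound 4 gives > 10000 nM, which is a limit and not a number. As far as these compounds go, the same change on the core of compound 1 cannot be read, so these compounds neither confirm nor refute that the change carries over from one core to the other, and its full size on the core of compound 2 stays unknown, because the values rest on one limit: the limit of > 10000 nM in this assay, at which 3 of the 4 values shown sit.

From the compounds shown here alone, whether another spatial arrangement at the 2 defined stereocentres of the 2-carboxycyclopropyl group would behave differently remains open. So does whether a shorter carboxymethyl or a longer 3-carboxypropyl chain on the same saturated ring carbon would give a readable number on either core.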